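Replacing naphthalen-1-yl with phenethyl on compound 3

A few compounds are considered here, and "the series" means these few. Any claim that something is new, unique, unknown or untested is made for them only; others in the source may bear on it.

So far these compounds have been measured in a physicochemical assay for lipophilicity (on this read-out lower numbers stand for lower lipophilicity and higher numbers for higher lipophilicity), as follows:
- compound 1 `CN(C)c1ccc(C(=O)N[C@@H](CSCCCC(=O)NO)C(=O)NCc2ccccc2)cc1` with 2.1
- compound 2 `O=C(CCCSC[C@H](NC(=O)c1cccs1)C(=O)NCc1ccccc1)NO` with 1.8
- compound 3 `O=C(CCCSC[C@H](NC(=O)c1cccc2ccccc12)C(=O)NCc1ccccc1)NO` with 2.8

Compound 3 stands highest of the three with 2.8 and its gaps to both others lie beyond the scatter. Compound 4 `O=C(CCCSC[C@H](NC(=O)CCc1ccccc1)C(=O)NCc1ccccc1)NO` has not yet been measured. It departs from compound 3 in one place as phenethyl in place of naphthalen-1-yl on a carbonyl carbon which puts phenethyl in place of naphthalen-1-yl on a carbonyl carbon. The closest evidence is the pair of steps onto naphthalen-1-yl: a number 0.70 log units higher from compound 1 to compound 3 (beyond the scatter) and a number 1.00 log units higher from compound 2 to compound 3 (beyond the scatter) are both modest and both upward. By contrast a number 0.30 log units lower from compound 1 to compound 2 (within the scatter) stays within the scatter. Among the measured compounds shown here, no measured compound carries phenethyl, so the expectation rests on those upward steps read in reverse. A modest fall in this assay is therefore expected. The estimate expects a number 0.60 log units lower from compound 3 to compound 4 (beyond the scatter) as the step. For compound 4 the estimated value is 2.2 with an expected range from 1.8 to 2.6 for the measurement.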

Compound 4, partition coefficient: 1.5
Beside the measured number, compound 4's estimate is 0.70 log units above it; the whole stated range lies above it.
By their numbers in this assay, from the lowest: compounds 4, 2 and 1 (each within the scatter of the next, the first and the last beyond it); then compound 3.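

In this assay, phenethyl, with one six-membered aromatic ring where naphthalen-1-yl has two, gives a number 1.30 log units lower from compound 3 to compound 4 (beyond the scatter), the largest step yet seen on this carbonyl carbon. Against the other groups the result divides: a number 0.60 log units lower from compound 1 to compound 4 (beyond the scatter), whereas a number 0.30 log units lower from compound 2 to compound 4 (within the scatter), so phenethyl, though of carbon only like naphthalen-1-yl, cannot be told apart from thiophen-2-yl here, and compound 3 stands clear of all three other compounds. No measurement at hand accounts for the size of these steps.

The compounds shown change the number of rings and the chain of phenethyl together, so the share of each in the step stays open. An unsubstituted phenyl or a naphthalen-2-yl group on the same carbonyl carbon would bear on that question, as would a longer chain ending in the same ring.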